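Changing the Group on a Carbonyl Carbon

The source may report more compounds than this note shows. Statements on the series, on what has been measured and on what is new or still open speak of the compounds shown alone.

In a functional assay on the whole organism for inhibition, with Cavia porcellus as the target (a higher number here means that more compound is needed for the effect, a lower number that less compound is needed), compound 1 (`COc1ccccc1OCC1SCCN1C(=O)Cn1ccnc1`) needs 50 mg/kg for the effect and compound 2 (`C=CC(=O)N1CCSC1COc1ccccc1OC`) needs 74 mg/kg for the same effect. Among the measured compounds shown here, these are the only two numbers available, and they lie within the usual scatter of each other, so compound 2 stands level with compound 1.

Compound 3 (`CCCC(=O)CC(=O)N1CCSC1COc1ccccc1OC`) keeps the shared core of compound 2 and differs in one place, with (propylcarbonyl)methyl in place of vinyl on a carbonyl carbon. The other neighbour of that carbon is an amide-type nitrogen in a ring.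

For the measured compounds named here, one measured step bears on this change, since it concerns the same carbonyl carbon, with vinyl in place of (1H-imidazol-1-yl)methyl (a 1.5-fold higher number from compound 1 to compound 2 (0.17 log units; within the scatter)). Going by the values given here, that step is small, but it is a single step, and no measured compound carries the incoming group. In this assay the estimated step is therefore expected to lie within the scatter (a 1.2-fold lower number from compound 2 to compound 3 (0.09 log units; within the scatter)). For compound 3 the estimated value is 60 mg/kg (expected range 25 mg/kg to 140 mg/kg).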

Compound 3, dose for half-maximal effect: 42 mg/kg
Compound 3: middle estimate off by 1.4-fold (0.15 log units), on the high side, and the stated range covers the measured number.
By their numbers in this assay, from the lowest: compounds 3, 1 and 2 (each within the scatter of the next).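

In this assay, the carbonyl carbon whose other neighbour is an amide-type nitrogen in a ring now carries a third group, (propylcarbonyl)methyl, and replacing vinyl with it gives a 1.8-fold lower number from compound 2 to compound 3 (0.25 log units; within the scatter). Putting propylcarbonyl in place of 1H-imidazol-1-yl on the saturated chain carbon bound to that carbonyl carbon gives a 1.2-fold lower number from compound 1 to compound 3 (0.08 log units; within the scatter), so all three groups seen here, including one of 6 heavy atoms with a hydrogen-bond acceptor and one of only 2 heavy atoms with none, give numbers that cannot be told apart at this position. No measurement is available that would explain these results.

As far as these compounds go, whether a different kind of group on this carbonyl carbon, such as an amine, a carboxylic acid or a longer chain than (propylcarbonyl)methyl, would move the number beyond the scatter remains open. Also open, from the compounds shown here alone, is whether any group here matters more once the shared core is changed, as all three compounds carry the same core.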